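Aryl variation on the ring-amide series, second step

A few compounds are considered here, and "the series" means these few. Any claim that something is new, unique, unknown or untested is made for them only; others in the source may bear on it.

The shared core carries a two-carbon link to an amide; compound 1 `CC1(c2ccccc2)CC(=O)N(CC(=O)N2CCOCC2)C1=O` closes that amide on a simple saturated ring and in a functional assay on the whole organism (strain CD-1) with Mus musculus as the target, in the maximal electroshock model, with a stated time of 2 h (on this read-out higher numbers stand for an effect only at larger amounts of compound and lower numbers for an effect already at smaller amounts), compound 1 gives 300 mg/kg. Compound 2 `CC1(c2ccccc2)CC(=O)N(CC(=O)N2CCN(c3ccccc3Cl)CC2)C1=O` and compound 3 `CC1(c2ccccc2)CC(=O)N(CC(=O)N2CCN(c3ccccc3)CC2)C1=O` instead close the amide on a six-membered non-aromatic ring with 2 nitrogen that bears an aromatic group. Compound 2 stands without any number: in this assay compound 2 is reported as "not active" (no number reported), and compound 3 is likewise reported as "not active" (no number reported). Only compound 1 gives a figure in this set.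

Compound 4 `CC1(c2ccccc2)CC(=O)N(CC(=O)N2CCN(c3ccc(F)cc3)CC2)C1=O` is the next member, not yet measured, and differs from compound 2 by 4-fluorophenyl in place of 2-chlorophenyl on an amine nitrogen in a ring. Among the compounds with values here, no measured step exists for this change. With compound 2 and compound 3 both without a figure, no shift in this assay beyond the scatter can be argued for compound 4; the expectation is that compound 4 most likely again returns no number. Should a figure appear, compound 4 is estimated at 300 mg/kg, with a range from 100 mg/kg to 600 mg/kg.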

Compound 4, minimum effective dose: 100 mg/kg
Estimate against measurement, compound 4: 3.0-fold (0.48 log units) above, within the range that was stated.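

In this assay, within the data shown here, compound 4 gives 100 mg/kg while compound 2 has no number, so no step between compound 2 and compound 4 can be read, and no measured evidence bears on this result. Still open, going by these compounds, is how 4-fluorophenyl compares in number with the aromatic groups of compound 2 and compound 3.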